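The source may report more compounds than this note shows. Statements on the series, on what has been measured and on what is new or still open speak of the compounds shown alone.

In an ADME assay on microsomes from liver (Homo sapiens) for metabolic stability, read by LC-MS, using NADPH, with a stated time of 30 min, tested at 1 uM (a higher number here means faster removal of the compound, a lower number slower removal), the values so far are these:

compound 1 (`CC(C)c1noc(N2CCC(Oc3cc(N4CCc5cc(C6CCCCC6=O)ccc54)ncn3)CC2)n1`) gives 78 mL.min-1.g-1
compound 2 (`CC(C)c1noc(N2CCC(Oc3cc(N4CCc5cc(N6CCCNS6(=O)=O)ccc54)ncn3)CC2)n1`) gives 79 mL.min-1.g-1
compound 3 (`CC(=O)N(C)c1ccc2c(c1)CCN2c1cc(OC2CCN(c3nc(C(C)C)no3)CC2)ncn1`) gives 173 mL.min-1.g-1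

Compound 3 stands highest of the three, and both steps leading to it are modest but beyond the scatter (a 2.2-fold higher number from compound 1 to compound 3 (0.35 log units; beyond the scatter); a 2.2-fold higher number from compound 2 to compound 3 (0.34 log units; beyond the scatter)). Compound 1 and compound 2 lie within the scatter of each other (a 1.0-fold higher number from compound 1 to compound 2 (0.01 log units; within the scatter)).

Compound 4 (`CC(C)c1noc(N2CCC(Oc3cc(N4CCc5cc(S(C)(=O)=O)ccc54)ncn3)CC2)n1`) carries methylsulfonyl in place of acetyl(methyl)amino on an aromatic carbon. Among the compounds with values here, no measured step involves methylsulfonyl, so the guide is indirect. Going by compound 1 (78 mL.min-1.g-1) and compound 2 (79 mL.min-1.g-1), a modest fall in this assay is expected, not a large one. The expected change is (a 2.2-fold lower number from compound 3 to compound 4 (0.33 log units; beyond the scatter)). For compound 4 the estimated value is 80 mL.min-1.g-1 with an expected range of (40 mL.min-1.g-1 to 150 mL.min-1.g-1).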

Compound 4, intrinsic clearance in microsomes: 69 mL.min-1.g-1
For compound 4 the middle estimate is 1.2-fold (0.06 log units) above the measured one; low and high end bracket the measured number.
By their numbers in this assay, from the lowest: compounds 4, 1 and 2 (each within the scatter of the next); then compound 3.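

In this assay, methylsulfonyl at this aromatic carbon does not keep the high number of acetyl(methyl)amino (a 2.5-fold lower number from compound 3 to compound 4 (0.40 log units; beyond the scatter)), so among these compounds an open-chain group here does not by itself bring faster removal. Without a ring, methylsulfonyl also sits level with 2-oxocyclohexyl (a 1.1-fold lower number from compound 1 to compound 4 (0.05 log units; within the scatter)) and with the ring of compound 2 (a 1.1-fold lower number from compound 2 to compound 4 (0.06 log units; within the scatter)), leaving compound 3 alone at the high end. Nothing measured here explains these numbers. The compounds shown leave open whether the acetyl or the methyl of acetyl(methyl)amino carries the difference, and where a plain acetylamino group or a carboxylic acid at this position would stand.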